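This account rests on a few compounds, and the source may have more. Where it says the series, first, only, none or still open, it means among the compounds named here.

Measured compounds in this series:

Compound 1, `COc1ccc(OC)c(CNC(=O)NS(=O)(=O)c2ccc(Cl)cc2)c1`. In a functional assay on thoracic aorta (Rattus norvegicus, strain Wistar), with a stated time of 15 min (a higher number here means that more compound is needed for the effect, a lower number that less compound is needed), compound 1 gives > 300000 nM, which is a limit of the assay and not a number.
Compound 2, `COc1ccc(OC)c(CNC(=O)NS(=O)(=O)c2ccccc2)c1`. In this assay compound 2 gives > 300000 nM, likewise a limit.
Compound 3, `CCOc1ccc(Br)cc1C(C)NC(=O)NS(=O)(=O)c1ccccc1`. In this assay compound 3 gives > 300000 nM, again a limit.

The difference between the cores of compound 2 and compound 3 is not broken down here. On the core of compound 2 the change to compound 1 is chloro in place of hydrogen on an aromatic carbon. The resulting step that the two limits leave unreadable from compound 2 to compound 1 stays unreadable because of the limit of > 300000 nM in this assay, at which 3 of the 3 values shown sit; both ends of the pair are limits, so no size can be assigned to it.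

Compound 4, `CCOc1ccc(Br)cc1C(C)NC(=O)NS(=O)(=O)c1ccc(Cl)cc1`, has not been measured in this assay. It carries the same kind of change on the core of compound 3, namely (chloro in place of hydrogen on an aromatic carbon); the two place descriptions agree word for word.

The expectation for compound 4 rests only on the measured pair: the same change from compound 2 to compound 1 left both values at the limit, and compound 3 itself sits at the limit. Compound 4 is therefore expected to report a limit as well, with an estimated value of 400000 nM in this assay, spanning 150000 nM to 1500000 nM. The step that the limit leaves unreadable from compound 3 to compound 4 is expected to be negligible.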

Compound 4, half-maximal effective concentration: 171000 nM
Compound 4: the middle estimate sits 2.3-fold (0.37 log units) above what was measured; low and high end bracket the measured number.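

In this assay, on these data alone, the change from phenyl to 4-chlorophenyl gives an at least 1.7-fold lower number from compound 3 to compound 4 (0.24 log units; that floor lies within the scatter), so on this core the change coincides with a value that leaves the assay limit, though the size of the step stays open and its floor cannot be told from scatter. Among the compounds shown here, the same change on the core of compound 2 gives a step that cannot be read, so the two cores offer no pair of sizes to compare: the limit of > 300000 nM in this assay, at which 3 of the 4 values shown sit. The series therefore shows one core on which the chloro comes with a readable number and one on which it does not, and it does not show that the change carries over from one core to another with a common size.

As far as these compounds go, it remains open whether a methyl, an amine or a carboxylic acid in place of the chloro would give a readable number on either core. Also open, from the compounds shown here alone, is whether any such group would move the core of compound 2 off its limit.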